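Replacing the 2-chlorophenyl group of compound 2 with a branched alkyl chain

This account rests on a few compounds, and the source may have more. Where it says the series, first, only, none or still open, it means among the compounds named here.

Within the data shown here, compound 2 `O=C(O)c1ccccc1-c1ccc(CCc2ncc(Cc3ccccc3Cl)[nH]2)cc1` is the only compound here with a measured number in an in vitro functional assay on cells for agonist activity at Bombesin receptor subtype-3 (Mus musculus), read by luminescence and calcium flux (on this read-out higher numbers stand for an effect only at larger amounts of compound and lower numbers for an effect already at smaller amounts), where compound 2 gives 22 nM. Compound 1 `CCCCc1cnc(Cc2ccc(-c3ccccc3C(=O)O)cc2)[nH]1` reaches only the limit of this assay, giving > 10000 nM. The evidence on hand is thus confined to the limit of > 10000 nM in this assay, at which 1 of the 2 values shown sits. Compound 3 `CCC(C)(CC)Cc1cnc(CCc2ccc(-c3ccccc3C(=O)O)cc2)[nH]1` differs from compound 2 in one place: 1-ethyl-1-methylpropyl in place of 2-chlorophenyl on a saturated chain carbon bound to an aromatic carbon. Among the measured compounds shown here, no measured pair in this set makes this kind of change, so its size can only be guessed. Compound 3 is expected to lose activity in this assay, and the step of a 27-fold higher number from compound 2 to compound 3 (1.44 log units; beyond the scatter) is estimated to lie well beyond the usual scatter, because compound 1, which also carries a branched or straight alkyl chain in place of a substituted phenyl ring, gives > 10000 nM. Compound 3 is therefore estimated at 600 nM, in a range from 80 nM to 6000 nM.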

Compound 3, half-maximal effective concentration: 30 nM
Compound 3: the middle estimate sits 20-fold (1.30 log units) above what was measured, and the stated range ends above it.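

In this assay, the step of a 1.4-fold higher number from compound 2 to compound 3 (0.13 log units; within the scatter) shows that an aromatic ring is not needed at this position, on a saturated chain carbon bound to an aromatic carbon: 1-ethyl-1-methylpropyl, with no ring and no chlorine, takes the place of 2-chlorophenyl with no change beyond the scatter. Compound 1 differs from compound 2 and compound 3 in more than one place, so its value, which is a limit of the assay, says nothing about this change alone. The data on hand give no cause for the match between these two groups.

Going by these compounds, it remains open how a group carrying an amine or a hydroxyl would fare at this position. A cyclohexyl ring or an unbranched pentyl chain in the same place is equally untested in what is shown here.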